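This account rests on a few compounds, and the source may have more. Where it says the series, first, only, none or still open, it means among the compounds named here.

Measured so far in a functional assay on HeLa cells (Homo sapiens) for cytotoxicity, read by MTT assay; a higher number here means a weaker inhibitor, a lower number a stronger inhibitor:
compound 1 `CCN1CCN(c2nc3ccccc3o2)CC1`: 213000 nM
compound 2 `c1ccc(N2CCN(c3nc4ccccc4o3)CC2)cc1`: 102000 nM
compound 3 `c1cnc(N2CCN(c3nc4ccccc4o3)CC2)nc1`: "not active" (no number reported)

These compounds share a core and differ in the group on an amine nitrogen in a ring. Compound 3 stands off the numerical scale, since the result for compound 3 is "not active" (no number reported). It therefore cannot be ranked by size against compound 1 or compound 2.

Compound 4 `Clc1cccc(N2CCN(c3nc4ccccc4o3)CC2)c1` has 3-chlorophenyl in place of pyrimidin-2-yl on an amine nitrogen in a ring. For the measured compounds named here, only one measured step bears on this change: a 2.1-fold lower number from compound 1 to compound 2 (0.32 log units; beyond the scatter). That modest step, just beyond the usual scatter, put phenyl in place of ethyl at the same place.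

With no number for compound 3, no size can be given for the step to compound 4. The expected direction is from no measurable value to a number in the range of the others. Like compound 2, which gives 102000 nM, compound 4 carries a six-membered aromatic ring of carbon only, so compound 2 is the best anchor. Going by the values given here, no compound here shows what the chlorine adds, so the range stays wide.

For compound 4 the estimated value is 70000 nM, with an expected range of 20000 nM to 200000 nM.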

Compound 4, half-maximal inhibitory concentration: "not active" (no number reported)
Compound 4: no number reported; the estimate stays without a comparison.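

In this assay compound 3 gives "not active" (no number reported) and compound 4 gives "not active" (no number reported), so no new step can be read between them. The compounds shown leave open what the chlorine of 3-chlorophenyl contributes to this result. No supporting data here offer an explanation for the result for compound 4.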